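Taking the iodo group off compound 2

The source may hold more compounds than are shown below. What is called first, only, known or untested is meant among the compounds shown, and "the series" means these compounds.

Measured in a functional assay on HeLa cells (Homo sapiens) for inhibition; on this read-out higher numbers stand for weaker inhibition and lower numbers for stronger inhibition:
- Compound 1 `O=C/C=C/n1cc(CO)c(=O)[nH]c1=O`: > 100000 nM (a limit)
- Compound 2 `O=C/C=C/n1c(=O)c(I)cn([C@H]2C[C@H](O)[C@@H](CO)O2)c1=O`: 15000 nM
- Compound 3 `Cc1cn([C@H]2C[C@H](O)[C@@H](CO)O2)c(=O)n(/C=C/CO)c1=O`: > 100000 nM (a limit)

Only compound 2, at 15000 nM, has a true number here. The other two results are not numbers: they mark (the limit of > 100000 nM in this assay, at which 2 of the 3 values shown sit). So the series gives one firm value and little else to compare it with.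

The next compound to be tested is compound 4 `O=C/C=C/n1c(=O)ccn([C@H]2C[C@H](O)[C@@H](CO)O2)c1=O`. It has hydrogen in place of iodo on an aromatic carbon of the shared core, and the rest of the structure is unchanged: hydrogen in place of iodo on an aromatic carbon.

Within the data shown here, no measured pair isolates this swap, so any forecast is uncertain. Compound 3 also carries no iodo, and it reaches only its limit of > 100000 nM, although it differs from compound 2 in other places too. This one comparison suggests some loss of inhibition, beyond the usual scatter of this assay, rather than no change. The expected step is a 2.7-fold higher number from compound 2 to compound 4 (0.43 log units; beyond the scatter), towards weaker inhibition. For compound 4 the estimate is 40000 nM, with an expected range of 10000 nM to 100000 nM.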

Compound 4, half-maximal inhibitory concentration: 15000 nM
Estimate against measurement, compound 4: 2.7-fold (0.43 log units) above; low and high end bracket the measured number.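

In this assay, putting hydrogen in place of iodo gives no change at the digits printed from compound 2 to compound 4 (within the scatter). Among these compounds, this is the first pair that differs in one place only, so it tests this swap directly, whereas the earlier compounds could offer only comparisons blurred by changes elsewhere in the structure. For this pair, the iodo on this aromatic carbon of the shared core, a single heavy atom, can be replaced by hydrogen with no measurable consequence for inhibition, so the iodo is not needed to keep the inhibition of compound 2 at this level.

Iodo and hydrogen are only two possibilities for this carbon, so it remains open whether a larger or differently built group, such as an amine, a nitrile or a carboxylic acid, would shift the number in either direction while the 2-formylethenyl group and the rest of the structure stay fixed. Any wider reading of the series also remains limited, since some of its results are not numbers: the limit of > 100000 nM in this assay, at which 2 of the 4 values shown sit.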